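The compounds below may be only part of what the source reports. "The series", "measured", "known", "first", "only" and "open" are said of these compounds alone.

Working notes on the series. Compound 1 `COC(=O)c1ccc(OCCCCOc2ccc(C(=O)CC3CCCC3)c(O)c2C)cc1` and compound 2 `COC(=O)c1ccc(OCCCCOc2ccc(C(=O)CC(C)C)c(O)c2C)cc1` share the same core and differ only at the saturated chain carbon bound to a carbonyl carbon. In an assay on HEK293 cells for positive allosteric modulation of metabotropic glutamate receptor 2 (Rattus norvegicus), read by thallium flux, with a stated time of 2.5 min (a lower number here means a smaller maximal response, a higher number a larger maximal response), compound 1 gives 12.2%, and compound 2 gives 16.4%. Compound 2 stands highest of the two numbers, but its step from compound 1, a number 4.2 percentage points higher from compound 1 to compound 2 (within the scatter), is within the scatter, so the two values show no real separation. Compound 3 `Cc1cc(OCCCCOc2ccc(C(=O)CC(C)C)c(O)c2C)ccc1C(=O)O` is not yet measured; it differs from compound 2 by 4-carboxy-3-methylphenyl in place of 4-(methoxycarbonyl)phenyl on an oxygen on a saturated carbon. For the measured compounds named here, the only measured step concerns a different part of the molecule and is within the scatter, so no measured step bears on this change; the data give no basis for a direction. With both measured values low, compound 3 is estimated at 14% in this assay, within 4% to 30%, which means an expected step of a number 2.4 percentage points lower from compound 2 to compound 3 (within the scatter) from compound 2 to compound 3.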

Compound 3, largest response reached (reported as percent of maximum), in percent of the reference or control that the assay uses: 93.3%
Compound 3: middle estimate off by 79.3 percentage points, on the low side; measured number above the stated range.
By their numbers in this assay, from the lowest: compounds 1 and 2 (each within the scatter of the next); then compound 3.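

The change to 4-carboxy-3-methylphenyl in place of 4-(methoxycarbonyl)phenyl on an oxygen on a saturated carbon gives a number 76.9 percentage points higher from compound 2 to compound 3 (beyond the scatter) in this assay. Unlike the change at the saturated chain carbon bound to a carbonyl carbon, a number 4.2 percentage points higher from compound 1 to compound 2 (within the scatter), this step lies beyond the scatter, so this position is the first in the series where a change clearly separates two compounds. No measured evidence here accounts for the size of this step.

The new group differs from the old one in two ways, a carboxylic acid in place of the methyl ester and an added ring methyl, and the compounds shown do not tell which of these carries the step. Also open, as far as these compounds go, is how a 4-carboxyphenyl group, without the methyl, or a tetrazole in place of the carboxylic acid would read in this assay.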